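Swapping tert-Butylphenyl for Methylindolyl on the Shared Core

The source may report more compounds than this note shows. Statements on the series, on what has been measured and on what is new or still open speak of the compounds shown alone.

Compound 3 `COc1cc(-c2ccnc3cc(-c4ccc(C(C)(C)C)cc4)nn23)cc(OC)c1OC` stands at the weak end of the numbers shown: in a functional assay on A549 cells (Homo sapiens) for inhibition, read by CCK-8 assay, with a stated time of 48 h (on this read-out lower numbers stand for stronger inhibition and higher numbers for weaker inhibition), compound 3 gives > 10000 nM, which is a limit of the assay rather than a number, and (the limit of > 10000 nM in this assay, at which 1 of the 3 values shown sits). Compound 1 `COc1ccc(-c2cc3nccc(-c4cc(OC)c(OC)c(OC)c4)n3n2)cc1N`, with the same core, gives 138 nM in this assay. Among the measured compounds shown here, the one measured step that bears on the change is an at least 72-fold higher number from compound 1 to compound 3 (1.86 log units; beyond the scatter), so what is attached at this carbon of the core matters greatly. Compound 2 `Cn1ccc2cc(-c3cc4nccc(-c5ccc(F)cc5)n4n3)ccc21`, which carries a methylindolyl group of a different kind and a different aryl group, gives 3520 nM in this assay. Compound 4 `COc1cc(-c2ccnc3cc(-c4ccc5ccn(C)c5c4)nn23)cc(OC)c1OC` differs from compound 3 by 1-methyl-1H-indol-6-yl in place of 4-(tert-butyl)phenyl on an aromatic carbon. The large step of an at least 72-fold higher number from compound 1 to compound 3 (1.86 log units; beyond the scatter) and the finite value of compound 2, 3520 nM, are the grounds for expecting some return of inhibition. Compound 3 being a limit leaves the size of the step uncertain. The step of an at least 3.3-fold lower number from compound 3 to compound 4 (0.52 log units; beyond the scatter) is expected to be a moderate gain. Compound 4 is therefore estimated at 3000 nM in this assay, within 800 nM to 10000 nM.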

Compound 4, half-maximal inhibitory concentration: 829 nM
Compound 4: the middle estimate sits 3.6-fold (0.56 log units) above what was measured, and the stated range covers the measured number.
By their numbers in this assay, from the lowest: compound 1; then compound 4; then compound 2. At a limit, above all of these: compound 3.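

In this assay, replacing 4-(tert-butyl)phenyl with 1-methyl-1H-indol-6-yl gives an at least 12-fold lower number from compound 3 to compound 4 (1.08 log units; beyond the scatter), so two groups with the same heavy-atom count can give very different numbers at this carbon. The value of compound 3 is a limit of the assay and not a number, so this step has no fixed size: the limit of > 10000 nM in this assay, at which 1 of the 4 values shown sits. The indole still does not match the group in compound 1, as the comparison shows a 6.0-fold higher number from compound 1 to compound 4 (0.78 log units; beyond the scatter), and so 3-amino-4-methoxyphenyl gives the lowest number of the three groups compared at this carbon.

The compounds shown leave open whether the amine or the methoxy group of 3-amino-4-methoxyphenyl accounts for that lead. A phenyl group carrying only the amine, or only the methoxy group, would separate the two.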